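Fluoro for trifluoromethyl: expected exposure of compound 4

This account rests on a few compounds, and the source may have more. Where it says the series, first, only, none or still open, it means among the compounds named here.

Among the measured compounds shown here, in an in vivo ADME assay on the whole organism for pharmacokinetics, with Mus musculus as the target, at a dose of 200 mg/kg by the intraperitoneal route (on this read-out higher numbers stand for higher exposure at the dose given and lower numbers for lower exposure), compound 3 (`CSc1ccc(C2=C(c3ccc(C(F)(F)F)cc3)C(=O)N3CCCC3C2)cc1`) gives 3790 nM, the lowest of the three numbers so far. Compound 2 (`CSc1ccc(C2=C(c3ccc(C)cc3)C(=O)N3CCCC3C2)cc1`) gives 8020 nM, and compound 1 (`COc1ccc(C2=C(c3ccc(SC)cc3)CC3CCCN3C2=O)cc1OC`) gives 23000 nM. Compound 4 (`CSc1ccc(C2=C(c3ccc(F)cc3)C(=O)N3CCCC3C2)cc1`) carries fluoro in place of trifluoromethyl on an aromatic carbon, para to a large group: fluoro in place of trifluoromethyl on an aromatic carbon. For the measured compounds named here, one measured step bears on this: trifluoromethyl in place of methyl on an aromatic carbon gave a 2.1-fold lower number from compound 2 to compound 3 (0.33 log units; beyond the scatter), modest but beyond the scatter. Going by the values given here, no measured step involves fluoro, so the expectation in this assay is only a modest rise, no larger than that step. The expected change is a 1.5-fold higher number from compound 3 to compound 4 (0.16 log units; within the scatter). For compound 4 the estimate is 5500 nM, with an expected range of 2500 nM to 12000 nM.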

Compound 4, maximal plasma concentration: 990 nM
Compound 4: the middle estimate sits 5.6-fold (0.74 log units) above what was measured; measured number outside the range, below it.
By their numbers in this assay, from the lowest: compound 4; then compound 3; then compound 2; then compound 1.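

In this assay fluoro, on an aromatic carbon para to a large group, gives the lowest number of the three groups compared at this place, with a 3.8-fold lower number from compound 3 to compound 4 (0.58 log units; beyond the scatter) and an 8.1-fold lower number from compound 2 to compound 4 (0.91 log units; beyond the scatter). The order on the shared core therefore runs methyl, then trifluoromethyl, then fluoro, each step beyond the scatter. No measurement at hand explains this order.

On these data alone, whether an amine, a carboxylic acid or a longer chain at this place would extend the order remains open. As far as these compounds go, whether fluoro would give a similar step on the core of compound 1 also remains open.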